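A Thioether Replaces a Benzylamine on the Shared Core

The source may hold more compounds than are shown below. What is called first, only, known or untested is meant among the compounds shown, and "the series" means these compounds.

Compound 1: `Nc1cc(N)c2nc(-c3ccccc3)c(Oc3ccc(Cl)c(Cl)c3)nc2c1`, < 100000 nM
Compound 2: `Nc1cc(N)c2nc(-c3ccccc3)c(NCc3ccc(F)cc3)nc2c1`, 53700 nM

Among the compounds with values here, in a functional assay on TK-10 cells (Homo sapiens) for inhibition, read by sulforhodamine B assay, with a stated time of 48 h (a higher number here means that more compound is tolerated, a lower number that less compound is tolerated), compound 2 gives 53700 nM, the only number among the values shown. Compound 1 reaches only a limit of the assay, < 100000 nM. Within the data shown here, the single measured step, a step that the limit leaves unreadable from compound 1 to compound 2, cannot be sized because of the limit of < 100000 nM in this assay, at which 1 of the 2 values shown sits. Compound 3, `COc1ccc(Sc2nc3cc(N)cc(N)c3nc2-c2ccccc2)cc1`, differs from compound 2 by (4-methoxyphenyl)sulfanyl in place of (4-fluorobenzyl)amino on an aromatic carbon. Among the measured compounds shown here, no measured step bears directly on this change, and the one step available is itself unreadable, so the expectation rests on compound 2 alone. Compound 3 is expected to show a step no larger than the scatter, a 1.1-fold higher number from compound 2 to compound 3 (0.05 log units; within the scatter), in no particular direction. The estimate for compound 3 in this assay is 60000 nM, within the range 20000 nM to 150000 nM, with a fair chance that only a limit is reported.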

Compound 3, concentration lethal to 50% of the cells: 72400 nM
For compound 3 the middle estimate is 1.2-fold (0.08 log units) below the measured one; measured number inside the range.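

In this assay, within the data shown here, (4-methoxyphenyl)sulfanyl in place of (4-fluorobenzyl)amino gives a 1.3-fold higher number from compound 2 to compound 3 (0.13 log units; within the scatter), the first readable step at this position. The entering group carries no hydrogen-bond donor and the leaving group does, yet compound 3 and compound 2 lie within the scatter of each other, so this exchange of one aromatic-ring substituent for another leaves the number unmoved in these two compounds. The value of compound 1 is only a limit, so the steps from compound 1 cannot be read: the limit of < 100000 nM in this assay, at which 1 of the 3 values shown sits.

The link atom and the substituent on the aromatic ring change together here, so neither can be read alone. From the compounds shown here alone, whether a group without an aromatic ring, such as a simple amine or a carboxylic acid, would move the number beyond the scatter at this position remains open.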